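Amino for Chloro on the Purine Core

This account rests on a few compounds, and the source may have more. Where it says the series, first, only, none or still open, it means among the compounds named here.

Within the data shown here, compound 1 `ClCc1ccccc1Cn1cnc2c(Cl)nc(Cl)nc21` holds the lowest number of the two compounds measured so far. In a functional assay on EKVX cells (Homo sapiens) for cytotoxicity, read by sulforhodamine B assay, with a stated time of 48 h (a lower number here means that less compound is tolerated, a higher number that more compound is tolerated), compound 1 gives 5880 nM. Among the measured compounds shown here, its only neighbour, compound 2 `Nc1nc(Cl)c2ncn(Cc3ccc(CCl)cc3)c2n1`, gives in this assay 28200 nM, a number that lies beyond the scatter above that of compound 1; the two compounds differ in more than one place, so no single step connects them. Compound 3 `Nc1nc(Cl)c2ncn(Cc3ccccc3CCl)c2n1` is not yet measured. It differs from compound 1 in one place: amino in place of chloro on an aromatic carbon, an amino in place of a chloro on an aromatic carbon. For the measured compounds named here, no measured pair isolates this change. Compound 2 carries the same amino on that carbon and shows the higher number, but its benzyl group is also substituted differently, so its value gives only a hint. Compound 3 is therefore expected to tolerate more compound than compound 1, with a step of a 2.6-fold higher number from compound 1 to compound 3 (0.41 log units; beyond the scatter) upward that is expected to reach beyond the scatter. The value of compound 3 in this assay is estimated at 15000 nM, with a range from 6000 nM to 40000 nM.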

Compound 3, concentration lethal to 50% of the cells: 60300 nM
Beside the measured number, compound 3's estimate is 4.0-fold (0.60 log units) below it, and the stated range ends below it.
By their numbers in this assay, from the lowest: compound 1; then compound 2; then compound 3.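

With nothing else on the shared core altered, replacing chloro with amino on the aromatic carbon between two ring nitrogen atoms gives, in this assay, a 10-fold higher number from compound 1 to compound 3 (1.01 log units; beyond the scatter). Earlier, the only sign of what this change might do came from a pair that differed in more than one place, whereas this single exchange shows that this position alone can carry a large shift in how much compound the cells tolerate, upward in this case. No measurement here explains why the step is this large.

The compounds shown leave open how other groups on this carbon would compare, such as a methoxy, a methylamino or a plain hydrogen, and whether the scale of the step belongs to amino in particular or would be reached by other replacements for chloro. They also leave open whether a step of this size would recur with the benzyl group substituted as in compound 2, and whether the chloro group that remains on the six-membered ring matters to the result.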